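Shedding the Benzyl Group from a Bridged Benzoxazole

This account rests on a few compounds, and the source may have more. Where it says the series, first, only, none or still open, it means among the compounds named here.

Of the compounds shown here, three sharing one bridged core have been measured in an assay on HEK293 cells for binding affinity to Neuronal acetylcholine receptor; alpha4/beta2 (Homo sapiens); on this read-out higher numbers stand for weaker inhibition and lower numbers for stronger inhibition. Compound 1, `c1ccc(-c2cccc3c2C2CNCC3C2)cc1`, carries a phenyl ring on its core and gives 1600 nM in this assay. Compound 2, `c1ccc(Cc2nc3cc4c(cc3o2)C2CNCC4C2)cc1`, has a five-membered ring with one nitrogen and one oxygen fused to the core and a benzyl group on that ring; in this assay compound 2 gives 34 nM. Compound 3, `Cc1nc2cc3c(cc2n1C)C1CNCC3C1`, bears only small methyl groups and gives 0.31 nM in this assay. Compound 2 therefore holds the second highest of the three numbers, its value closer to that of compound 1 than to that of compound 3, and both gaps lie beyond the usual scatter.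

Compound 4, `c1nc2cc3c(cc2o1)C1CNCC3C1`, is compound 2 with the benzyl group stripped away: hydrogen in place of benzyl on an aromatic carbon. For the measured compounds named here, no measured pair shows exactly this change, so the expectation rests on the whole set. The smaller the group on the core, the lower the numbers run across compounds 1, 2 and 3, so a step down from compound 2 to compound 4 of the size a 14-fold lower number from compound 2 to compound 4 (1.13 log units; beyond the scatter) is expected, beyond the scatter. Compound 4 is thus estimated at 2.5 nM in this assay, most likely between 0.3 nM and 20 nM.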

Compound 4, inhibition constant: 0.16 nM
Compound 4: middle estimate off by 16-fold (1.19 log units), on the high side, outside the stated range (below it).
By their numbers in this assay, from the lowest: compounds 4 and 3 (each within the scatter of the next); then compound 2; then compound 1.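

In this assay, hydrogen in place of benzyl gives a 210-fold lower number from compound 2 to compound 4 (2.33 log units; beyond the scatter), a large step well beyond the usual scatter. Compounds 1, 2 and 3 differ from one another in more than one place and could not single out this position, but here only the group on the aromatic carbon of the five-membered ring changes, so the whole step belongs to that swap: of the two groups seen on this carbon, the one with no heavy atom goes with the far lower number, and the seven carbons of benzyl, with their six-membered aromatic ring, go with the far higher one. Nothing in the data given explains why removing the benzyl group has so large an effect.

From the compounds shown here alone, with only hydrogen and benzyl seen at this position, it remains open how the number changes for groups of intermediate size, such as an ethyl group or a short chain ending in an amine. Going by these compounds, it is also open whether the same swap would give a step of similar size on a core with a different fused ring.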